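Solubility notes on a dichlorophenyl series: cyanomethyl to fluoropyridyl

The compounds below may be only part of what the source reports. "The series", "measured", "known", "first", "only" and "open" are said of these compounds alone.

Three compounds have numbers in a physicochemical assay for solubility, measured as kinetic solubility, with a stated time of 1 h, at pH 7.4; a lower number here means a less soluble compound, a higher number a more soluble compound: compound 1 `CS(=O)(=O)Nc1nc(-c2ccc(Cl)c(Cl)c2)cs1` gives 429000 nM, compound 2 `N#CCC(=O)Nc1cc(-c2ccc(Cl)c(Cl)c2)cs1` gives 12000 nM, and compound 3 `N#CCC(=O)NC1=NN(c2ccc(Cl)c(Cl)c2)CC1` gives 202000 nM. Compound 3 stands second highest of the three; its nearest neighbour is compound 1, which lies higher and beyond the scatter, while compound 2 sits far lower.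

Compound 4 `O=C(NC1=NN(c2ccc(Cl)c(Cl)c2)CC1)c1cccnc1F` differs from compound 3 in one place: 2-fluoropyridin-3-yl in place of cyanomethyl on a carbonyl carbon. Among the measured compounds shown here, no pair of measured compounds shows this change, so the expected step rests on judgement only. A downward step beyond the scatter is expected for compound 4 in this assay, of about a 4.0-fold lower number from compound 3 to compound 4 (0.61 log units; beyond the scatter). Compound 4 is estimated at 50000 nM, ranging from 15000 nM to 150000 nM.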

Compound 4, solubility: 13000 nM
Compound 4: middle estimate off by 3.8-fold (0.59 log units), on the high side; measured number outside the range, below it.
By their numbers in this assay, from the lowest: compounds 2 and 4 (each within the scatter of the next); then compound 3; then compound 1.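

In this assay, 2-fluoropyridin-3-yl in place of cyanomethyl on a carbonyl carbon gives a large fall (a 16-fold lower number from compound 3 to compound 4 (1.19 log units; beyond the scatter)). Among the compounds shown here, the earlier compounds offered no pair differing in one place, so this is the first sign that this position alone can shift the number so strongly. Nothing measured here bears on the reason for the step.

Going by these compounds, whether the fall tracks the aromatic ring, the fluorine or simply the larger group remains open. Also unsettled is how a phenyl group, a short alkyl chain or an amine would behave on the same carbonyl carbon.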